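A hydroxycyclobutyl chain at the clearance limit

The source may report more compounds than this note shows. Statements on the series, on what has been measured and on what is new or still open speak of the compounds shown alone.

In an in vitro ADME assay on microsomes from Gut (Homo sapiens) for metabolic stability, using NADPH (on this read-out higher numbers stand for fast clearance and lower numbers for slow clearance), compound 3 (`CC(O)CCNC(=O)c1cc2cc(C#N)ccc2n1Cc1cccc(OC(F)(F)F)c1`) gives < 6 mL.min-1.g-1, which is a limit and not a number. Compound 2 (`CC(C)(O)CCNC(=O)c1cc2cc(C#N)ccc2n1Cc1cccc(OC(F)(F)F)c1`) gives < 6 mL.min-1.g-1, also a limit. Compound 1 (`Cc1ccc(Cl)cc1Cn1c(C(=O)NCC(C)(C)CO)cc2cc(C#N)ccc21`) gives < 6 mL.min-1.g-1, again a limit. Every reading so far therefore comes down to the limit of < 6 mL.min-1.g-1 in this assay, at which 3 of the 3 values shown sit, and compound 3 has no number of its own to stand on.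

Compound 4 (`N#Cc1ccc2c(c1)cc(C(=O)NCCC1(O)CCC1)n2Cc1cccc(OC(F)(F)F)c1`) has not yet been measured. It differs from compound 3 by 1-hydroxycyclobutyl in place of 1-hydroxyethyl on a saturated chain carbon, two bonds along the chain from an amide-type nitrogen.

Within the data shown here, only one measured step bears on this change, a step that the two limits leave unreadable from compound 2 to compound 3, as it also alters a saturated chain carbon bound to an oxygen. Its size cannot be read, as both of its ends are limits. It therefore offers no size or direction to carry over, and no change beyond the usual scatter is expected in this assay. The expected step, a step that the limit leaves unreadable from compound 3 to compound 4, is an estimate that carries little weight. The expectation rests on compound 3, whose reading is the limit < 6 mL.min-1.g-1. A limit rather than a number is the likeliest report for compound 4. The estimate for compound 4 is 5 mL.min-1.g-1, with an expected range from 2.5 mL.min-1.g-1 to 10 mL.min-1.g-1.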

Compound 4, intrinsic clearance in microsomes: < 6 mL.min-1.g-1
Compound 4: a limit, no number; the forecaster's own chance of this, stated with the estimate: 75%; the middle value is on the limit's open side.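

In this assay, among these compounds, compound 2, compound 3 and compound 4 all stand as limits and not numbers, and no step among them can be read: the limit of < 6 mL.min-1.g-1 in this assay, at which 4 of the 4 values shown sit. The compounds shown leave open how fast each of them is actually cleared, and whether 1-hydroxycyclobutyl in place of 1-hydroxyethyl changes that clearance at all.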